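Moving the ring methyl within the pyridyl urea series

The source may hold more compounds than are shown below. What is called first, only, known or untested is meant among the compounds shown, and "the series" means these compounds.

Compound 1 `CC(C)N(CCN(C(=O)N(C)C)c1ccccn1)C(C)C` and compound 2 `Cc1ccnc(N(CCN(C(C)C)C(C)C)C(=O)N(C)C)c1` share one core and differ only at an aromatic carbon. In a functional assay on the whole organism (stomach) for inhibition, with Canis familiaris (Canis lupus familiaris) as the target, at a dose of 20 mg/kg by the oral route (a higher number here means a stronger effect of the compound at the dose given, a lower number a weaker effect), compound 1 gives 17%. In this assay compound 2 gives 95%. For the measured compounds named here, the single measured step, a number 78 percentage points higher from compound 1 to compound 2 (beyond the scatter), comes from methyl in place of hydrogen on an aromatic carbon. Compound 2 therefore stands highest of the two numbers, and its nearest neighbour, compound 1, lies below it by a margin beyond the scatter.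

Compound 3 `Cc1ccc(N(CCN(C(C)C)C(C)C)C(=O)N(C)C)nc1` is not yet measured. Its change from compound 2 is 5-methylpyridin-2-yl in place of 4-methylpyridin-2-yl on an amide-type nitrogen. The methyl is kept; only the carbon it sits on changes. Going by the values given here, no measured step moves a methyl between aromatic carbons, so the only bearing comes from a number 78 percentage points higher from compound 1 to compound 2 (beyond the scatter), which shows that a ring methyl in the 4-methylpyridin-2-yl arrangement is worth a large gain. From the compounds shown here alone, whether the 5-methylpyridin-2-yl arrangement keeps that gain is unknown. Compound 3 is expected to keep most of it, giving a step of a number 30 percentage points lower from compound 2 to compound 3 (beyond the scatter) in this assay. The estimate for compound 3 is 65%, within 25% to 95%.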

Compound 3, a percentage reported as inhibition, in the whole organism at one dose (the size of the read-out at that dose, not a potency): 19%
Compound 3: the middle estimate sits 46 percentage points above what was measured; measured number below the stated range.
By their numbers in this assay, from the lowest: compounds 1 and 3 (each within the scatter of the next); then compound 2.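

In this assay the gain from the ring methyl proves to depend on the carbon that carries it: 5-methylpyridin-2-yl in place of 4-methylpyridin-2-yl on the amide-type nitrogen gives a number 76 percentage points lower from compound 2 to compound 3 (beyond the scatter), although the two groups match in every count of atoms, donors and acceptors. Methyl in place of hydrogen in the 5-methylpyridin-2-yl arrangement gives a number 2 percentage points higher from compound 1 to compound 3 (within the scatter), so here the methyl cannot be told apart from the hydrogen of compound 1, while the 4-methylpyridin-2-yl arrangement alone carries a number 78 percentage points higher from compound 1 to compound 2 (beyond the scatter), and that earlier step cannot be read as a general effect of a ring methyl. Nothing at hand bears on why the two arrangements part so sharply.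

From the compounds shown here alone, whether the high reading of compound 2 survives with an ethyl, a methoxy or a chlorine in place of the methyl on that same carbon stays open. Going by these compounds, the read-out gives the size of the effect at one dose, so how compound 2 and compound 3 compare at any other dose also stays open.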